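One amide substituent change and what it may bring

The source may hold more compounds than are shown below. What is called first, only, known or untested is meant among the compounds shown, and "the series" means these compounds.

In a functional assay on MDA-MB-231 cells (Homo sapiens) for cytotoxicity, read by MTT assay, with a stated time of 72 h (a higher number here means a weaker inhibitor, a lower number a stronger inhibitor), compound 1 (`COc1ccc(NC(=O)CN2CCN(c3nnc(Cc4ccncc4)c4ccccc34)CC2)cc1OC`) gives 100 nM and compound 3 (`O=C(CN1CCN(c2nnc(Cc3ccncc3)c3ccccc23)CC1)Nc1cccc(Br)c1`) gives 1.7 nM as its number. Compound 2 (`O=C(CN1CCN(c2nnc(Cc3ccccc3)c3ccccc23)CC1)Nc1c(F)cccc1F`) gives 5490 nM as the highest number of the three, which places it as the weakest inhibitor of the set. Compound 4 (`O=C(CN1CCN(c2nnc(Cc3ccccc3)c3ccccc23)CC1)Nc1ccc(F)c(C(F)(F)F)c1`) departs from compound 2 in one place (4-fluoro-3-(trifluoromethyl)phenyl in place of 2,6-difluorophenyl on an amide-type nitrogen), with 4-fluoro-3-(trifluoromethyl)phenyl in place of 2,6-difluorophenyl on an amide-type nitrogen. For the measured compounds named here, one measured step bears on that nitrogen (a 59-fold lower number from compound 1 to compound 3 (1.77 log units; beyond the scatter)), where 3-bromophenyl replaced 3,4-dimethoxyphenyl. That step shows how far a change on this nitrogen can move the number in this assay for this pair, but it involves neither group at issue here, and compounds 1 and 3 also differ from compound 2 elsewhere in the structure. A fluorine-bearing ring is no guide by itself, since compound 2 is the only such case measured. Going by the values given here, with compound 2 at the top of the measured numbers and the one relevant step running downward, a drop is expected, though with wide uncertainty. The expected change is a large one (a 27-fold lower number from compound 2 to compound 4 (1.44 log units; beyond the scatter)) toward a lower number. Compound 4 is therefore estimated at 200 nM (expected range 10 nM to 4000 nM).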

Compound 4, half-maximal inhibitory concentration: 760 nM
Compound 4: middle estimate off by 3.8-fold (0.58 log units), on the low side; the measured number falls inside the stated range.
By their numbers in this assay, from the lowest: compound 3; then compound 1; then compound 4; then compound 2.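

In this assay, replacing the ring on the amide-type nitrogen gives a 7.2-fold lower number from compound 2 to compound 4 (0.86 log units; beyond the scatter), which shows that this position also responds to a change when the rest of the molecule is that of compound 2. The earlier step at this nitrogen, a 59-fold lower number from compound 1 to compound 3 (1.77 log units; beyond the scatter), was read on the core of compound 1 and could not show this. Both rings in the new step carry fluorine, yet their numbers differ beyond the scatter, so the presence of fluorine on this ring does not by itself set the number, and no measurement shown here explains the difference between the two rings.

On these data alone, it remains open whether 3-bromophenyl would give a similarly low number on the core of compound 2, and whether 4-fluoro-3-(trifluoromethyl)phenyl would keep its advantage over 2,6-difluorophenyl on the core of compound 1. The compounds shown also leave open how this assay would read with a ring carrying a carboxylic acid or an amine on the amide-type nitrogen, or with a longer alkyl chain there in place of the ring.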